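Shortening a Long Chain on Compound 1

The source may hold more compounds than are shown below. What is called first, only, known or untested is meant among the compounds shown, and "the series" means these compounds.

Compound 1 `CCCCCCCCCCCCCCCCCC(=O)Nc1nnc(S[C@@H]2O[C@H](COC(C)=O)[C@H](OC(C)=O)[C@H](OC(C)=O)[C@H]2OC(C)=O)s1` gives 23600 nM in a functional assay on MDA-MB-231 cells (Homo sapiens) for cytotoxicity, read by MTT assay, with a stated time of 24 h; a lower number here means a stronger inhibitor, a higher number a weaker inhibitor.
Compound 2 `CCCCCCCCCCCC(=O)Nc1nnc(S[C@@H]2O[C@H](CO)[C@H](O)[C@H](O)[C@H]2O)s1` gives 32000 nM in this assay.
Compound 3 `CCCCCCCC(=O)Nc1nnc(S[C@@H]2O[C@H](CO)[C@H](O)[C@H](O)[C@H]2O)s1` gives 30800 nM in this assay.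

All three numbers sit within the usual scatter of one another, so compound 1 cannot be set apart from compound 2 or compound 3. Compound 4 `CCCCCCCC(=O)Nc1nnc(S[C@@H]2O[C@H](COC(C)=O)[C@H](OC(C)=O)[C@H](OC(C)=O)[C@H]2OC(C)=O)s1` differs from compound 1 in one place: hydrogen in place of decyl on a saturated chain carbon, seven bonds along the chain from a carbonyl carbon. For the measured compounds named here, one measured step bears on this, the one with the same kind of cut at the same place: a 1.0-fold lower number from compound 2 to compound 3 (0.02 log units; within the scatter), a change too small to count. The same outcome is therefore expected here, with no step beyond the scatter, a 1.0-fold higher number from compound 1 to compound 4 (0.01 log units; within the scatter). Compound 4 is expected to give about 24000 nM in this assay, somewhere between 12000 nM and 48000 nM.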

Compound 4, half-maximal inhibitory concentration: 18900 nM
Compound 4: middle estimate off by 1.3-fold (0.10 log units), on the high side; the range from low to high includes it.
By their numbers in this assay, from the lowest: compounds 4, 1, 3 and 2 (each within the scatter of the next).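

In this assay the removal of decyl gives a 1.2-fold lower number from compound 1 to compound 4 (0.10 log units; within the scatter), so even this large cut at this place on the chain leaves the number unmoved. The earlier step removed only butyl, from a compound with free hydroxyl groups, while this one removes decyl from a compound carrying acetyl groups, and the result again stays within the scatter. No measurement at hand explains this insensitivity to the chain. Still open, on these data alone, is whether an amine or a carboxylic acid in place of that hydrogen would shift the number.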